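From methoxy to difluoromethoxy in compound 1

A few compounds are considered here, and "the series" means these few. Any claim that something is new, unique, unknown or untested is made for them only; others in the source may bear on it.

Going by the values given here, in an ADME assay on a cell-free system (plasma, Rattus norvegicus) for protein binding, compound 1 `CNc1nccc(N2CC[C@H](NC(=O)Nc3ccc(OC)cc3)C2)n1` gives 86.3%, which leaves it with the largest free share of the three compounds measured so far. Compound 2 `CNc1nccc(N2CC[C@H](NC(=O)Nc3ccc(Cl)c(C(F)(F)F)c3)C2)n1` gives 99.7%, and compound 3 `CNc1nccc(N2CC[C@H](NC(=O)Nc3ccc(C)c(Cl)c3)C2)n1` gives 98.9%. All three share one core and differ in the aromatic group on an amide-type nitrogen.

Compound 4 `CNc1nccc(N2CC[C@H](NC(=O)Nc3ccc(OC(F)F)cc3)C2)n1` has not yet been measured. It departs from compound 1 by a single change, difluoromethyl in place of methyl on an oxygen on an aromatic ring. Among the compounds with values here, no measured step makes this exact swap. The closest is 3-chloro-4-methylphenyl in place of 4-methoxyphenyl on an amide-type nitrogen, a 12-fold lower unbound fraction from compound 1 to compound 3 (1.10 log units; beyond the scatter). That swap replaces the whole aromatic group, whereas here only the methyl leaves, so a smaller step in the same direction is expected, an estimated a 2.0-fold lower unbound fraction from compound 1 to compound 4 (0.29 log units; within the scatter). For compound 4 the expected value in this assay is 93%, with an estimated range from 88% to 97%.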

Compound 4, plasma protein binding: 97.7%
The estimate for compound 4 lay 3.0-fold (0.48 log units) (unbound fraction) above the measured number; measured number above the stated range.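

Placing difluoromethyl instead of methyl on the oxygen gives, in this assay, a 6.0-fold lower unbound fraction from compound 1 to compound 4 (0.77 log units; beyond the scatter). The earlier step, a 12-fold lower unbound fraction from compound 1 to compound 3 (1.10 log units; beyond the scatter), replaced the whole aromatic group, so it could not separate the contribution of any one part of that group. The new step does isolate one part: with the shared core and the rest of the aromatic group unchanged, altering only the group on this oxygen is enough to move plasma protein binding beyond the usual scatter. The compounds shown leave open how this position responds to other groups on the same oxygen, such as ethyl, a longer chain, or a hydroxyethyl chain ending in an alcohol. Why difluoromethyl shifts the binding in this way also remains open, with no measurement here that bears on the cause.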